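The compounds below may be only part of what the source reports. "The series", "measured", "known", "first", "only" and "open" are said of these compounds alone.

Compound 1 `COc1ccc(Cn2cc(/C=N\NC(=O)c3c[nH]c4ccc(Br)cc34)c3ccc(F)cc32)cc1` and compound 2 `COc1ccc(Cn2cc(/C=N\NC(=O)c3c[nH]c4ccccc34)c3ccc(F)cc32)cc1` share one core; compound 3 `O=C(N/N=C\c1cn(Cc2ccc(Cl)cc2)c2ccc(Br)cc12)c1c[nH]c2ccccc12` and the unmeasured compound 4 `O=C(N/N=C\c1cn(Cc2ccc(Cl)cc2)c2ccccc12)c1c[nH]c2ccccc12` share another. In a functional assay on MIA PaCa-2 cells (Homo sapiens) for cytotoxicity (a lower number here means a stronger inhibitor, a higher number a weaker inhibitor), compound 1 gives 45500 nM, and compound 2 gives 43300 nM. The change between these two is hydrogen in place of bromo on an aromatic carbon and the step it made is a 1.1-fold lower number from compound 1 to compound 2 (0.02 log units; within the scatter). Compound 3 gives 8700 nM in this assay; the difference between its core and the core of compound 1 is not broken down here. Compound 4 differs from compound 3 by hydrogen in place of bromo on an aromatic carbon, the same change made once before among these compounds. Since the earlier step was a 1.1-fold lower number from compound 1 to compound 2 (0.02 log units; within the scatter), the step of a 1.0-fold higher number from compound 3 to compound 4 (0.01 log units; within the scatter) is expected to be small as well. Compound 4 is therefore estimated at 9000 nM in this assay, expected to fall between 4500 nM and 18000 nM.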

Compound 4, half-maximal inhibitory concentration: 44300 nM
For compound 4 the middle estimate is 4.9-fold (0.69 log units) below the measured one, outside the stated range (above it).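

Hydrogen in place of bromo does not carry over unchanged between these two cores in this assay: the same change on two cores in this assay, a 1.1-fold lower number (0.02 log units; within the scatter) from compound 1 to compound 2 and a 5.1-fold higher number (0.71 log units; beyond the scatter) from compound 3 to compound 4, 5.4-fold (0.73 log units) apart, beyond the scatter of two such steps

On the core of compound 3 the change gives a 5.1-fold higher number from compound 3 to compound 4 (0.71 log units; beyond the scatter) and so cannot be treated as neutral there, even though it made no difference beyond the scatter on the core of compound 1. Two pairs show only that the outcome depends on the core; they do not show which difference between the cores is responsible, and they give no rule for a further core.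

The compounds shown leave open whether a different group at that aromatic carbon, such as an amine or a carboxylic acid, would keep the lower number of compound 3.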